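Benzoyl capping of the aniline nitrogen in compound 4

The source may hold more compounds than are shown below. What is called first, only, known or untested is meant among the compounds shown, and "the series" means these compounds.

Compound 1 `COc1ccc(CNC(=O)c2cnc3nc(C)ccc3c2O)cc1` gives > 10000 nM in an assay for binding affinity to adenosine receptor A1 (Bos taurus); a lower number here means a stronger inhibitor, a higher number a weaker inhibitor; this value is a limit of the assay. Compound 2 `Cc1ccc2c(O)c(C(=O)NCc3ccc([N+](=O)[O-])cc3)cnc2n1` gives 1630 nM in this assay. Compound 3 `Cc1ccc2c(O)c(C(=O)NCc3ccc(N)cc3)cnc2n1` gives 2860 nM in this assay.

Among the numbers shown, compound 3 and compound 2 lie within the scatter of each other a 1.8-fold higher number from compound 2 to compound 3 (0.24 log units; within the scatter); apart from these two, only a limit is known (the limit of > 10000 nM in this assay, at which 1 of the 3 values shown sits). Compound 4 `Cc1ccc2c(O)c(C(=O)NCc3ccc(NC(=O)c4ccccc4)cc3)cnc2n1` differs from compound 3 by benzoyl in place of hydrogen on a nitrogen on an aromatic ring. The measured steps that come closest are the two exchanges on the same aromatic carbon, an at least 6.1-fold lower number from compound 1 to compound 2 (0.78 log units; beyond the scatter) and an at least 3.4-fold lower number from compound 1 to compound 3 (0.54 log units; beyond the scatter), both at least modest; the exchange between those two groups, a 1.8-fold higher number from compound 2 to compound 3 (0.24 log units; within the scatter), is within the scatter. None of them concerns acylation of the amino nitrogen, so the bearing of the benzoyl group on this assay can only be guessed from the tolerance this position has shown. The step of a 1.1-fold lower number from compound 3 to compound 4 (0.06 log units; within the scatter) is therefore expected to stay within the scatter, with no clear direction. For compound 4 the estimate in this assay is 2500 nM, with a range from 600 nM to 10000 nM.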

Compound 4, inhibition constant: 7590 nM
For compound 4 the middle estimate is 3.0-fold (0.48 log units) below the measured one; the range from low to high includes it.
By their numbers in this assay, from the lowest: compounds 2 and 3 (each within the scatter of the next); then compound 4. At a limit, above all of these: compound 1.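

Benzoyl on the amino nitrogen moves the number beyond the scatter, a 2.7-fold higher number from compound 3 to compound 4 (0.42 log units; beyond the scatter), a modest step, whereas the exchange between nitro and amino on the same aromatic carbon had stayed within it. The benzamido group also stands modestly apart from nitro, a 4.7-fold higher number from compound 2 to compound 4 (0.67 log units; beyond the scatter), so in this assay this position does not treat every group alike, although compound 4 still gives a measurable 7590 nM. The exchange for methoxy gives only a floor, an at least 1.3-fold lower number from compound 1 to compound 4 (0.11 log units; that floor lies within the scatter), which settles no order, and the value of compound 1 is a limit: the limit of > 10000 nM in this assay, at which 1 of the 4 values shown sits.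

Going by these compounds, it remains open whether the higher number belongs to the benzoyl group with its aromatic ring or to acylation of this nitrogen as such, which an acetyl or a methanesulfonyl group on the same nitrogen would help separate. On these data alone, it is also open how a dimethylamino group or a carboxylic acid on the same aromatic carbon would compare, and whether any group there would give a number clearly lower than those of compound 2 and compound 3.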